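This account rests on a few compounds, and the source may have more. Where it says the series, first, only, none or still open, it means among the compounds named here.

Of the compounds shown here, three have so far been measured in an assay on CHO cells for activation of Guanylate cyclase soluble subunit alpha-1 (Rattus norvegicus), read by luminescence and cGMP accumulation, with a stated time of 6 min; a lower number here means a smaller maximal response, a higher number a larger maximal response. Compound 1 `Cc1c(CCC(=O)O)cccc1NC(=O)[C@H](c1ccc(Cl)cc1)C1CCCC1` gives 19%, compound 2 `C[C@H]([C@H](C(=O)Nc1cc(CC2(C(=O)O)CC2)ccc1Cl)c1ccc(Cl)cc1)C(F)(F)F` gives 63%, and compound 3 `C[C@H]([C@H](C(=O)Nc1cc(C2(CC(=O)O)CCC2)ccc1Cl)c1ccc(Cl)cc1)C(F)(F)F` gives 37%. For the measured compounds named here, compound 3 thus stands second of the three, with compound 1 below it and compound 2 above it, and the single one-place step known, a number 26 percentage points lower from compound 2 to compound 3 (beyond the scatter), lies beyond the scatter. Compound 4 `C[C@H]([C@H](C(=O)Nc1cc(C2(CC(=O)O)COC2)ccc1Cl)c1ccc(Cl)cc1)C(F)(F)F` differs from compound 3 in one place only: 3-(carboxymethyl)oxetan-3-yl in place of 1-(carboxymethyl)cyclobutyl on an aromatic carbon. Going by the values given here, no measured step swaps one four-membered ring for another in this way, so the known step offers no direct guide, and no shift beyond the scatter is expected. For compound 4 in this assay a value of 35% is estimated, between 20% and 55%. This estimate means a number 2 percentage points lower from compound 3 to compound 4 (within the scatter) is expected.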

Compound 4, largest response reached (reported as efficacy), in percent of the reference or control that the assay uses: 52%
The estimate for compound 4 lay 17 percentage points below the measured number; the range from low to high includes it.
By their numbers in this assay, from the lowest: compound 1; then compound 3; then compound 4; then compound 2.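

Placing one ring oxygen in the four-membered ring on this aromatic carbon changes the result in this assay, with a number 15 percentage points higher from compound 3 to compound 4 (beyond the scatter), so the ring atoms at this position are not interchangeable. The 3-(carboxymethyl)oxetan-3-yl group still does not match (1-carboxycyclopropyl)methyl, with a number 11 percentage points lower from compound 2 to compound 4 (beyond the scatter) as the step between them. Nothing at hand explains either step. Going by these compounds, whether the gain is specific to oxygen remains open, as an azetidine ring carrying a ring nitrogen could test, and so does the effect of a longer chain ending in a tetrazole.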